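Shortening the Side Chain of Compound 1

A few compounds are considered here, and "the series" means these few. Any claim that something is new, unique, unknown or untested is made for them only; others in the source may bear on it.

Measured so far in a functional assay on OE21 cells (Homo sapiens) for cytotoxicity, read by MTT assay, with a stated time of 72 h; a higher number here means a weaker inhibitor, a lower number a stronger inhibitor:
- Compound 1 `COc1cc(/C=C/C=O)cc(OC)c1OC/C=C(\C)CCC=C(C)C`: 27000 nM
- Compound 2 `C=C(C)CCOc1c(OC)cc(/C=C/CO)cc1OC`: > 100000 nM

For the measured compounds named here, compound 1 holds the only exact number so far. The value of compound 2 is a limit of the assay, not a number, so no true gap to compound 1 can be read from it.

Compound 3 `COc1cc(/C=C/C=O)cc(OC)c1OCC=C(C)C` keeps the core of compound 1 and changes one place: hydrogen in place of 3-methylbut-2-en-1-yl on a saturated chain carbon bound to a double-bonded chain carbon.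

Going by the values given here, no measured pair shows what this change does in this assay. A modest move towards a higher number, meaning a weaker inhibitor, seems the likeliest outcome, though it may stay close to the scatter. The expected change is a 1.7-fold higher number from compound 1 to compound 3 (0.22 log units; within the scatter). For compound 3 the estimated value is 45000 nM, with an expected range from 18000 nM to 100000 nM.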

Compound 3, half-maximal inhibitory concentration: 29000 nM
For compound 3 the middle estimate is 1.6-fold (0.19 log units) above the measured one; low and high end bracket the measured number.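

In this assay, replacing the 3-methylbut-2-en-1-yl group with hydrogen gives a 1.1-fold higher number from compound 1 to compound 3 (0.03 log units; within the scatter), so a part of the side chain with 5 carbon atoms can go without a change that can be told apart from the scatter. This is the first pair shown that differs in one place, which makes it the first direct reading of this position; the earlier compounds offered no such comparison. Compound 2 gives only a limit of the assay, not a number, and it differs from compound 1 in more than one place: the limit of > 100000 nM in this assay, at which 1 of the 3 values shown sits.

On these data alone, what the shorter chain kept in compound 3 contributes to the activity remains open. One step also cannot say whether an amine, a carboxylic acid or a longer chain at this place would shift the number.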